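Flavone acetamides: methoxy to phenyl on the anilide

The source may report more compounds than this note shows. Statements on the series, on what has been measured and on what is new or still open speak of the compounds shown alone.

Compound 1 `COc1ccc(NC(=O)COc2c(-c3ccccc3)oc3ccccc3c2=O)cc1` and compound 2 `O=C(COc1c(-c2ccccc2)oc2ccccc2c1=O)Nc1ccc(-c2ccccc2)cc1` share one core; compound 3 `COc1ccc(NC(=O)COc2ccc3c(=O)cc(-c4ccccc4)oc3c2)cc1` and compound 4 `O=C(COc1ccc2c(=O)cc(-c3ccccc3)oc2c1)Nc1ccc(-c2ccccc2)cc1` share another, and the difference between the two cores is not broken down here. In a functional assay on MT2 cells (Homo sapiens) for antiproliferative activity, read by MTT assay, with a stated time of 72 h (a higher number here means a weaker inhibitor of growth, a lower number a stronger inhibitor of growth), compound 1 gives only a limit, > 10000 nM. Compound 2 likewise gives only a limit in this assay, > 10000 nM. Compound 3 gives 6700 nM in this assay. The change from compound 1 to compound 2 is phenyl in place of methoxy on an aromatic carbon, and the step that the two limits leave unreadable from compound 1 to compound 2 is unreadable because of the limit of > 10000 nM in this assay, at which 2 of the 3 values shown sit. The same change, (phenyl in place of methoxy on an aromatic carbon), carries compound 3 to compound 4. For the measured compounds named here, with the only measured instance unreadable, a small step is expected from compound 3 to compound 4, a 1.3-fold higher number from compound 3 to compound 4 (0.13 log units; within the scatter), resting on compound 3 at 6700 nM. Compound 4 is thus expected at 9000 nM, in the range 3000 nM to 30000 nM.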

Compound 4, concentration for 50% growth inhibition: 2480 nM
The estimate for compound 4 lay 3.6-fold (0.56 log units) above the measured number; the whole stated range lies above it.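

In this assay, phenyl in place of methoxy on an aromatic carbon gives a 2.7-fold lower number from compound 3 to compound 4 (0.43 log units; beyond the scatter), so on the core of compound 3 the change lowers the number. On the core of compound 1 the same change cannot be read, and its carry-over between the two cores stays unshown, because compound 1 and compound 2 each give only a limit: the limit of > 10000 nM in this assay, at which 2 of the 4 values shown sit.
This leaves one readable instance on one core, which gives no rule for the series.

The compounds shown leave open how an amine, a carboxylic acid or a longer chain on that aromatic carbon would compare with phenyl on the core of compound 3. Also open, going by these compounds, is whether any such group would give a readable number on the core of compound 1.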